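The source may hold more compounds than are shown below. What is called first, only, known or untested is meant among the compounds shown, and "the series" means these compounds.

The study centres on a shared core that carries an arylamino group at one end and an enone-linked phenyl ring at the other. Compound 1, `COc1cccc(/C=C/C(=O)c2sc(Nc3ccc(Cl)c(Cl)c3)nc2C)c1`, pairs a dichloroanilino group with a methoxy-bearing phenyl ring; in a functional assay on PC-3 cells (Homo sapiens) for cytotoxicity, read by MTT assay (on this read-out lower numbers stand for stronger inhibition and higher numbers for weaker inhibition), compound 1 gives 10100 nM. Compound 2, `Cc1ccccc1Nc1nc(C)c(C(=O)/C=C/c2ccccc2)s1`, carries instead a methyl-substituted anilino group and an unsubstituted phenyl ring. For compound 2 this assay reports only a limit, > 25000 nM, not a number. That limit, (the limit of > 25000 nM in this assay, at which 1 of the 2 values shown sits), marks where compound 2 stands: its activity cannot be read from the numbers beyond the fact that it is no stronger than the limit itself.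

Compound 3, `COc1cccc(/C=C/C(=O)c2sc(Nc3ccccc3C)nc2C)c1`, keeps everything of compound 2 except one change, (methoxy in place of hydrogen on an aromatic carbon). Within the data shown here, compound 1 shows that a methoxy-bearing phenyl can coexist with measurable, if weak, activity, but compound 1 also differs in its anilino group, so no single step can be drawn from it. Compound 3 is therefore expected to move little, an at least 1.2-fold lower number from compound 2 to compound 3 (0.09 log units; that floor lies within the scatter), and to remain weak, with an estimated value of 20000 nM in this assay, expected between 8000 nM and 50000 nM.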

Compound 3, half-maximal inhibitory concentration: > 25000 nM
Compound 3 was reported as a limit; the forecaster's own chance of this, stated with the estimate: 55%; middle value at least 1.2-fold (0.09 log units) from the limit.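

In this assay compound 3 is reported only as a limit, > 25000 nM, so the step between compound 2 and compound 3 cannot be read, and nothing can be said about the size of the change from phenyl to 3-methoxyphenyl. The result does add a comparison that compounds 1 and 2 alone could not give, as they differ in two places, whereas compound 1 and compound 3 share the 3-methoxyphenyl and differ only in the group on the nitrogen: 2-methylphenyl in place of 3,4-dichlorophenyl gives an at least 2.4-fold higher number from compound 1 to compound 3 (0.39 log units; beyond the scatter). The two compounds carrying 2-methylphenyl on the nitrogen now both stand at the edge of what this read-out reports: the limit of > 25000 nM in this assay, at which 2 of the 3 values shown sit.

The compounds shown leave open whether the methoxy matters at all when 3,4-dichlorophenyl sits on the nitrogen, as they do not include that group paired with an unsubstituted phenyl. They also leave open whether a hydroxyl or an amine in place of the methoxy, or a single chlorine on the phenyl on the nitrogen, would give a value that can be read as a number.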